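Aryl replacement on the shared core toward compound 4

The compounds below may be only part of what the source reports. "The series", "measured", "known", "first", "only" and "open" are said of these compounds alone.

Measured compounds:
compound 1 `COc1ccc(C2Oc3ccccc3N(CCCCCN3C(C)CCCC3C)C2=O)cc1`: 2.3%
compound 2 `CC1CCCC(C)N1CCCCCN1C(=O)C(c2ccc(Cl)cc2)Oc2ccccc21`: 46%
compound 3 `CC1CCCC(C)N1CCCCCN1C(=O)C(c2ccc(C(=N)NO)cc2)Oc2ccccc21`: 8%

In an assay on isolated protein for inhibition of serine protease 1 (Homo sapiens), tested at 100 uM (a lower number here means less inhibition, a higher number more inhibition at the concentration tested (going by the name of the read-out)), compound 3 gives 8%, the second highest of the three numbers. Its nearest neighbour is compound 1, a difference within the scatter, as shown by a number 5.7 percentage points higher from compound 1 to compound 3 (within the scatter). Within the data shown here, its furthest is compound 2: the step of a number 38 percentage points lower from compound 2 to compound 3 (beyond the scatter) is large and beyond the scatter, the only substantial movement so far, driven by a number 43.7 percentage points higher from compound 1 to compound 2 (beyond the scatter) in the other direction.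

Compound 4 `C/N=C(/N)c1cccc(C2Oc3ccccc3N(CCCCCN3C(C)CCCC3C)C2=O)c1` differs from compound 3 by a group of 10 heavy atoms (8 carbon, 2 nitrogen; one six-membered aromatic ring of carbon only) in place of a group of 10 heavy atoms (7 carbon, 2 nitrogen, 1 oxygen; one six-membered aromatic ring of carbon only), on a saturated ring carbon. Among the measured compounds shown here, no measured step covers either the entering group or its placement on the aromatic ring; the two steps that reach compound 3 only show that groups other than chlorine on this ring give low numbers. With compound 1 at 2.3% and compound 3 at 8%, the step of a number 4 percentage points higher from compound 3 to compound 4 (within the scatter) is expected to stay within the scatter. Compound 4 is estimated at 12%, with a range from 0% to 40%.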

Compound 4, a percentage reported as inhibition, at one concentration (the size of the read-out at that concentration, not a potency): 32%
Estimate against measurement, compound 4: 20 percentage points below, and the stated range covers the measured number.
By their numbers in this assay, from the lowest: compounds 1 and 3 (each within the scatter of the next); then compound 4; then compound 2.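

In this assay, replacing the aryl group on the saturated ring carbon next to the ring oxygen can raise the number without chlorine: a number 24 percentage points higher from compound 3 to compound 4 (beyond the scatter) and a number 29.7 percentage points higher from compound 1 to compound 4 (beyond the scatter). Low numbers are therefore not general for aromatic rings without chlorine at this position, although the chlorine-bearing group still gives the highest number, with a number 14 percentage points lower from compound 2 to compound 4 (beyond the scatter). No measurement on hand accounts for these steps.

The entering group differs from the one it replaces both in its substituent and in where that substituent sits on the aromatic ring, and the compounds shown do not separate these two changes. Going by these compounds, it also remains open whether a nitrile or a carboxylic acid placed on the aromatic ring as in compound 4 would give a similar number.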